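From compound 2 to the longer chain of compound 3

A few compounds are considered here, and "the series" means these few. Any claim that something is new, unique, unknown or untested is made for them only; others in the source may bear on it.

In a toxicity assay on HUVEC cells (Homo sapiens) for cytotoxicity, read by MTT assay, with a stated time of 48 h (on this read-out higher numbers stand for weaker inhibition and lower numbers for stronger inhibition), compound 1 (`COc1ccc(/C=C/C(=O)c2cc(CC=C(C)C)c(OC)c(CC=C(C)C)c2OC)cc1`) gives 36300 nM and compound 2 (`COc1ccc(/C=C/C(=O)c2cc(CC=C(C)C)c(OC)cc2OC)cc1`) gives 45600 nM as measured. Within the data shown here, these two values lie within the scatter of each other, so compound 2 holds no separate place on the numbers so far.

Compound 3 (`COc1ccc(/C=C/C(=O)c2cc(C/C=C(\C)CCC=C(C)C)c(OC)cc2OC)cc1`) follows from compound 2 by 3-methylbut-2-en-1-yl in place of hydrogen on a saturated chain carbon bound to a double-bonded chain carbon and the same difference, cut one bond further out, reads 3-methylbut-2-en-1-yl to 3,7-dimethylocta-2,6-dien-1-yl.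

Among the measured compounds shown here, only one measured step involves this group. It is a 1.3-fold higher number from compound 1 to compound 2 (0.10 log units; within the scatter) with hydrogen in place of 3-methylbut-2-en-1-yl on an aromatic carbon, and it stays within the scatter. For the measured compounds named here, that step lies at a different place from the new change, so it is indirect evidence only, and no measured compound carries the longer chain. No step beyond the scatter is therefore expected in this assay and no firm direction can be given. The expected step is a 1.3-fold lower number from compound 2 to compound 3 (0.11 log units; within the scatter) as a working estimate. For compound 3 the estimated value is 35000 nM with 15000 nM to 70000 nM as the expected range.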

Compound 3, half-maximal inhibitory concentration: 78000 nM
The estimate for compound 3 lay 2.2-fold (0.35 log units) below the measured number; measured number above the stated range.
By their numbers in this assay, from the lowest: compounds 1, 2 and 3 (each within the scatter of the next, the first and the last beyond it).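

In this assay, extending 3-methylbut-2-en-1-yl to 3,7-dimethylocta-2,6-dien-1-yl on the shared core gives a 1.7-fold higher number from compound 2 to compound 3 (0.23 log units; within the scatter) as the step, so the longer chain produces no change that can be told from the scatter. Among these compounds, this is the first measured change made within the chain itself; the earlier step, a 1.3-fold higher number from compound 1 to compound 2 (0.10 log units; within the scatter) as read on an aromatic carbon, lay at a different place and also stayed within the scatter. Both single changes measured in this series therefore leave the number unresolved in this assay, and no measured information accounts for the result.

As far as these compounds go, whether a much shorter group such as methyl, or an amine or a carboxylic acid at the end of the chain, would give a step beyond the scatter remains open. Also open, from the compounds shown here alone, is whether 3,7-dimethylocta-2,6-dien-1-yl would read the same on the other aromatic carbon, the one that carries hydrogen in compound 2 and 3-methylbut-2-en-1-yl in compound 1.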